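Bromo to Trifluoromethyl on the Sulfonyl Aryl

The source may report more compounds than this note shows. Statements on the series, on what has been measured and on what is new or still open speak of the compounds shown alone.

Measured compounds:
compound 1 `O=S(=O)(NCCCNc1nccc(-c2c(-c3cccc(F)c3)nc3sccn23)n1)c1cccc(F)c1` gives 8550 nM
compound 2 `O=S(=O)(NCCNc1nccc(-c2c(-c3cccc(F)c3)nc3sccn23)n1)c1ccc(Br)cc1` gives 13500 nM
compound 3 `O=C(NCCNc1nccc(-c2c(-c3cccc(F)c3)nc3sccn23)n1)c1c(F)cccc1F` gives 11400 nM

In a functional assay on SK-MEL-28 cells (Homo sapiens) for cytotoxicity, read by MTT assay (on this read-out higher numbers stand for weaker inhibition and lower numbers for stronger inhibition), compound 2 has the highest of the three numbers, though a 1.6-fold higher number from compound 1 to compound 2 (0.20 log units; within the scatter) and a 1.2-fold lower number from compound 2 to compound 3 (0.07 log units; within the scatter) are both within the scatter, so the three compounds are not separated. Compound 4 `O=S(=O)(NCCNc1nccc(-c2c(-c3cccc(F)c3)nc3sccn23)n1)c1ccc(C(F)(F)F)cc1` differs from compound 2 by trifluoromethyl in place of bromo on an aromatic carbon. Among the measured compounds shown here, no measured pair changes this substituent; the steps that bear on it are those at the same aryl group, a 1.6-fold higher number from compound 1 to compound 2 (0.20 log units; within the scatter) and a 1.2-fold lower number from compound 2 to compound 3 (0.07 log units; within the scatter), both small. Compound 4 is therefore expected to show no step beyond the scatter, a 1.0-fold lower number from compound 2 to compound 4 (0.02 log units; within the scatter). The estimate for compound 4 is 13000 nM, with a range from 6000 nM to 30000 nM.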

Compound 4, half-maximal inhibitory concentration: 8450 nM
For compound 4 the middle estimate is 1.5-fold (0.19 log units) above the measured one, within the range that was stated.
By their numbers in this assay, from the lowest: compounds 4, 1, 3 and 2 (each within the scatter of the next).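

In this assay, among the compounds shown here, trifluoromethyl in place of bromo on an aromatic carbon, para to a large group, gives a 1.6-fold lower number from compound 2 to compound 4 (0.20 log units; within the scatter), the first measured step at this substituent. Exchanging one heavy atom for four therefore does not separate these two compounds, and all four compounds remain within the scatter of the next. No measurement shown here accounts for this result. On these data alone, whether an amine or a carboxylic acid in place of the trifluoromethyl would give a step beyond the scatter remains open.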